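The source may report more compounds than this note shows. Statements on the series, on what has been measured and on what is new or still open speak of the compounds shown alone.

For the measured compounds named here, in a functional assay on HL-60 cells (Homo sapiens) for inhibition, read by MTT assay, with a stated time of 72 h (on this read-out higher numbers stand for weaker inhibition and lower numbers for stronger inhibition), compound 1 (`COc1cc(OC)cc(N2CCN(C(=O)c3onc(C)c3-c3ccccc3F)CC2)c1`) gives 165 nM as the only number so far. Compound 2 (`C=C(C)c1ccc(N2CCN(C(=O)c3oc(C)nc3-c3ccccc3)CC2)cc1`) is recorded as "not active" (no number reported) with no number reported, so no step can be read from that pair. Compound 3 (`COc1cc(OC)cc(N2CCN(C(=O)c3onc(C)c3-c3ccccc3)CC2)c1`) is not yet measured. It differs from compound 1 in one place (hydrogen in place of fluoro on an aromatic carbon): hydrogen in place of fluoro on an aromatic carbon, ortho to a large group, turning 2-fluorophenyl into phenyl. Going by the values given here, no measured pair tests this change, so the expectation rests on compound 1 at 165 nM alone. In this assay the expected step (a 1.2-fold higher number from compound 1 to compound 3 (0.06 log units; within the scatter)) is none beyond the scatter, with no direction favoured. Compound 3 is estimated at 190 nM with an expected range of 70 nM to 500 nM for now.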

Compound 3, half-maximal inhibitory concentration: 152 nM
Estimate against measurement, compound 3: 1.3-fold (0.10 log units) above; the measured number falls inside the stated range.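

In this assay, this pair gives the series its first readable step at this position: hydrogen in place of fluoro on an aromatic carbon, ortho to a large group, gives a 1.1-fold lower number from compound 1 to compound 3 (0.04 log units; within the scatter). On this core, the 2-fluorophenyl of compound 1 and the phenyl of compound 3 cannot be told apart, so the fluoro is not required to hold the activity seen here. Nothing available bears on why the two compounds match.

The compounds shown carry only fluoro and hydrogen at this place, so it remains open whether a chloro, a trifluoromethyl or an amine there would leave the number within the scatter. For the compounds shown here, compound 2 has no number, so no step involving it can be read, and what the other parts of the core contribute also stays open.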